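The source may report more compounds than this note shows. Statements on the series, on what has been measured and on what is new or still open speak of the compounds shown alone.

Three compounds were examined in a functional assay on A-431 cells (Homo sapiens) for cytotoxicity, read by MTT assay, with a stated time of 72 h, tested at 100 uM; a higher number here means more inhibition of growth at the concentration tested, a lower number less inhibition of growth. Compound 1 `Cc1cccc(/C(N)=N/NC(=S)N2CCCCC2)n1` carries piperidin-1-yl on a thiocarbonyl carbon, and in this assay compound 1 gives 77.5%. Compound 2 `Cc1cccc(/C(N)=N/NC(=S)N2CCCC2)n1` differs from it by a single change, (pyrrolidin-1-yl in place of piperidin-1-yl on a thiocarbonyl carbon), and in this assay compound 2 gives 86.8%. The resulting step, a number 9.3 percentage points higher from compound 1 to compound 2 (within the scatter), is small. Compound 3 `Cc1ccnc(/C(N)=N/NC(=S)N2CCCCC2)c1` is built from the same atoms as compound 1, joined differently; how the two cores differ is not broken down here. In this assay compound 3 gives 77.6%, a number that sits close to that of compound 1 and within the scatter of compound 2.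

Compound 4 `Cc1ccnc(/C(N)=N/NC(=S)N2CCCC2)c1` has not yet been measured. It stands to compound 3 as compound 2 stands to compound 1: the change is pyrrolidin-1-yl in place of piperidin-1-yl on a thiocarbonyl carbon, the same change at the same place, and among the four compounds it occurs twice in all. Among the measured compounds shown here, since the only earlier instance of this change stayed within the scatter, the new step is expected to be modest as well. The step expected here is a number 6.4 percentage points higher from compound 3 to compound 4 (within the scatter), because the same change earlier gave a number 9.3 percentage points higher from compound 1 to compound 2 (within the scatter). With a single precedent on a different core, the range around this expectation is kept wide. Compound 4 is therefore expected to give 84%, with the result estimated to fall between 72% and 94%.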

Compound 4, percent growth inhibition at one concentration: 86.9%
Estimate against measurement, compound 4: 2.9 percentage points below; the range from low to high includes it.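

In this assay, pyrrolidin-1-yl in place of piperidin-1-yl on a thiocarbonyl carbon gives a second step on a different core, a number 9.3 percentage points higher from compound 3 to compound 4 (within the scatter). Set beside the earlier step, the change carries from one core to the other with no difference that can be told apart: the same change on two cores in this assay, a number 9.3 percentage points higher (within the scatter) from compound 1 to compound 2 and a number 9.3 percentage points higher (within the scatter) from compound 3 to compound 4, 0 percentage points apart, within the scatter of two such steps This agreement shows only that the two cores behave alike for this one change at the single concentration tested; each step lies within the scatter on its own, so the pair does not establish that the change really alters growth inhibition, and two cores cannot show that the same would hold on any other core.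

The compounds shown leave open how other groups on the thiocarbonyl carbon would compare with these two rings, for instance morpholin-4-yl, azepan-1-yl or an open-chain amine such as dimethylamino. They also leave open whether the agreement between the two cores would persist if the methyl group on each core gave way to another group, such as chlorine or a longer alkyl chain.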